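The compounds below may be only part of what the source reports. "The series", "measured", "known", "first", "only" and "open" are said of these compounds alone.

Compound 1, `O=C(Nc1cc(C(F)(F)F)cc(C(F)(F)F)c1)c1cc(Cl)c(-c2ccccc2)cc1O`: 430 nM
Compound 2, `O=C(Nc1ccc(C(F)(F)F)cc1)c1cc(Cl)c(-c2ccccc2)cc1O`: 770 nM
Compound 3, `O=C(Nc1ccc(C(F)(F)F)cc1)c1cc(Br)ccc1O`: 610 nM

All three were tested in a functional assay on KG-1 cells (Homo sapiens) for cytotoxicity, read by luminescence and CellTiter-Glo, with a stated time of 3 days; a lower number here means a stronger inhibitor, a higher number a weaker inhibitor. Compound 1 gives the lowest of the three numbers, but its gaps to compound 3 and to compound 2 both fall within the usual scatter, so the three cannot be ordered with confidence. Compound 4, `O=C(Nc1cc(C(F)(F)F)cc(C(F)(F)F)c1)c1cc(Br)c(-c2ccccc2)cc1O`, is not yet measured. It differs from compound 1 in one place: bromo in place of chloro on an aromatic carbon. Going by the values given here, no measured pair shows this exchange, so there is no step to lean on. Trading one halogen for another at the same spot usually shifts numbers little, so the step from compound 1 to compound 4 in this assay is expected to be none beyond the scatter. Compound 4 is estimated at 400 nM, within 200 nM to 800 nM. That estimate implies a step of a 1.1-fold lower number from compound 1 to compound 4 (0.03 log units; within the scatter).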

Compound 4, half-maximal inhibitory concentration: 300 nM
For compound 4 the middle estimate is 1.3-fold (0.12 log units) above the measured one, within the range that was stated.
By their numbers in this assay, from the lowest: compounds 4, 1, 3 and 2 (each within the scatter of the next, the first and the last beyond it).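

At the position ortho to a phenyl group and para to a hydroxy group, bromo in place of chloro gives a 1.4-fold lower number from compound 1 to compound 4 (0.16 log units; within the scatter) in this assay, so this exchange of one halogen for the other leaves no readable change. This is the first pair shown that differs only at this position on the shared core. Nothing measured here accounts for the step.

Going by these compounds, it remains open whether a group other than a halogen, such as an amine or a carboxylic acid, would be tolerated at this position. Also open, on these data alone, is whether the same exchange would read alike on the core of compound 2.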